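Notes on 3-fluorophenyl to 4-bromophenyl on the amide nitrogen

This account rests on a few compounds, and the source may have more. Where it says the series, first, only, none or still open, it means among the compounds named here.

In a functional assay on MCF7 cells (Homo sapiens) for inhibition, read by MTT assay, with a stated time of 48 h (on this read-out lower numbers stand for stronger inhibition and higher numbers for weaker inhibition), compound 1 (`COc1cc(/C=C/C(=O)NO)ccc1OCC(=O)Nc1ccccc1F`) gives > 100000 nM as a limit of the assay, not a number. Among the compounds with values here, compound 2 (`COc1cc(/C=C/C(=O)NO)ccc1OCC(=O)Nc1cccc(F)c1`) gives 39500 nM and holds the only true number so far. Within the data shown here, the one measured step runs an at least 2.5-fold lower number from compound 1 to compound 2 (0.40 log units; beyond the scatter) and rests on that limit (the limit of > 100000 nM in this assay, at which 1 of the 2 values shown sits). It exchanges 2-fluorophenyl for 3-fluorophenyl, so it bears only loosely on what comes next. Compound 3 (`COc1cc(/C=C/C(=O)NO)ccc1OCC(=O)Nc1ccc(Br)cc1`) carries 4-bromophenyl in place of 3-fluorophenyl on an amide-type nitrogen. Among the measured compounds shown here, no measured step exchanges the halogen itself. For the measured compounds named here, the only guide is the modest step to compound 2, which reads 39500 nM in this assay, so a small shift toward a lower number is expected, possibly none beyond the scatter. The estimated step runs a 1.6-fold lower number from compound 2 to compound 3 (0.20 log units; within the scatter) on this reasoning. For compound 3 the estimate is 25000 nM, with an expected range from 8000 nM to 80000 nM in this read-out.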

Compound 3, half-maximal inhibitory concentration: 73600 nM
For compound 3 the middle estimate is 2.9-fold (0.47 log units) below the measured one; measured number inside the range.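

In this assay, the exchange on the amide-type nitrogen gives a 1.9-fold higher number from compound 2 to compound 3 (0.27 log units; within the scatter), so 4-bromophenyl and 3-fluorophenyl, which differ in both halogen and ring number, are not separated by this read-out. Compound 1 gives > 100000 nM, which is a limit of the assay and not a number. The comparison with 4-bromophenyl reads an at least 1.3-fold lower number from compound 1 to compound 3 (0.13 log units; that floor lies within the scatter), so the step seen earlier for 3-fluorophenyl does not recur beyond the scatter here, and this reading rests on a limit: the limit of > 100000 nM in this assay, at which 1 of the 3 values shown sits.

No pair shown keeps the ring number fixed while exchanging fluorine for bromine, so the halogen alone remains unresolved. Also open, going by these compounds, is whether an unsubstituted phenyl, or a phenyl carrying an amine or a carboxylic acid, would move the number beyond the scatter in this assay.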